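This account rests on a few compounds, and the source may have more. Where it says the series, first, only, none or still open, it means among the compounds named here.

Measured compounds in the series:

- compound 1 `N#CC1=C(N)Oc2c(N)cc3nc4ccccc4nc3c2C12C(=O)N(Cc1cnnn1-c1cccc(C(F)(F)F)c1)c1ccccc12` gives 18900 nM in a functional assay on HCT-116 cells (Homo sapiens) for antiproliferative activity, read by MTT assay, with a stated time of 48 h; on this read-out lower numbers stand for stronger inhibition and higher numbers for weaker inhibition
- compound 2 `COc1ccccc1-n1nncc1CN1C(=O)C2(C(C#N)=C(N)Oc3c(N)cc4nc5ccccc5nc4c32)c2ccccc21` gives > 50000 nM in this assay; this is a limit of the assay, not a number
- compound 3 `CCc1cccc(CC)c1-n1nncc1CN1C(=O)C2(C(C#N)=C(N)Oc3c(N)cc4nc5ccccc5nc4c32)c2ccccc21` gives 37600 nM in this assay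

Compound 3 carries the highest of the two numbers in this assay; compound 1 is nearest to it, and that gap a 2.0-fold higher number from compound 1 to compound 3 (0.30 log units; within the scatter) is within the scatter. The remaining value, that of compound 2, is only a limit (the limit of > 50000 nM in this assay, at which 1 of the 3 values shown sits).

Compound 4 `N#CC1=C(N)Oc2c(N)cc3nc4ccccc4nc3c2C12C(=O)N(Cc1cnnn1-c1cc(Cl)ccc1Cl)c1ccccc12` has not yet been measured. It differs from compound 3 in one place: 2,5-dichlorophenyl in place of 2,6-diethylphenyl on an aromatic nitrogen.

Going by the values given here, three measured steps concern the same position, all swaps of the aryl group on the aromatic nitrogen. From compound 1 to compound 2 the change was an at least 2.6-fold higher number from compound 1 to compound 2 (0.42 log units; beyond the scatter); from compound 1 to compound 3 it was a 2.0-fold higher number from compound 1 to compound 3 (0.30 log units; within the scatter); from compound 2 to compound 3 it was an at least 1.3-fold lower number from compound 2 to compound 3 (0.12 log units; that floor lies within the scatter). None of these involves a dichlorophenyl group, and the two steps that yield numbers stay close to each other. A step within the scatter is therefore expected for a 1.4-fold lower number from compound 3 to compound 4 (0.16 log units; within the scatter), with some chance that this assay returns only a limit for compound 4, as it did for compound 2.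

Compound 4 is estimated at 26000 nM in this assay, with a range of 10000 nM to 60000 nM.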

Compound 4, half-maximal inhibitory concentration: > 50000 nM
Compound 4: a limit, no number (the forecaster's own chance of this, stated with the estimate: 30%); middle value at least 1.9-fold (0.28 log units) away from the limit.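

In this assay compound 4 gives > 50000 nM, which is a limit of the assay and not a number. The swap to 2,5-dichlorophenyl gives an at least 2.6-fold higher number from compound 1 to compound 4 (0.42 log units; beyond the scatter) and an at least 1.3-fold higher number from compound 3 to compound 4 (0.12 log units; that floor lies within the scatter), so only the first of these steps clears the scatter, and the step between compound 2 and compound 4 cannot be read, as both values are limits. Two different aryl groups on this aromatic nitrogen now return no number, leaving 3-(trifluoromethyl)phenyl and 2,6-diethylphenyl as the only groups shown that do: the limit of > 50000 nM in this assay, at which 2 of the 4 values shown sit.

Going by these compounds, how far compound 2 and compound 4 lie past the limit remains unknown, so their order stays open. Also open, on these data alone, is whether an aryl group carrying an amine or a carboxylic acid would return a number in this assay, and how that number would compare with compound 1.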